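A few compounds are considered here, and "the series" means these few. Any claim that something is new, unique, unknown or untested is made for them only; others in the source may bear on it.

Working notes on the series. In an assay on isolated protein for inhibition of serine/threonine-protein kinase 10 (Homo sapiens), read by thermal shift assay, tested at 10 uM (a higher number here means that the compound stabilises the target more against heat, a lower number that the compound stabilises the target less), compound 3 `CC(C)(C)c1cc(NC(=O)Nc2ccc(Cl)cc2)n(-c2ccc(S(C)(=O)=O)cc2)n1` stands highest of the three measured compounds with 4.1 degrees C. Compound 2 `CC(C)(C)c1cc(NC(=O)Nc2ccc(Cl)cc2)n(-c2ccc(C#N)cc2)n1` gives 2.2 degrees C and compound 1 `CC(C)(C)c1cc(NC(=O)Nc2ccc(Cl)cc2)n(-c2ccc(OC(F)(F)F)cc2)n1` gives 0 degrees C. The three measured steps all change the group at the same place: a number 2.2 degrees C higher from compound 1 to compound 2 (beyond the scatter), a number 4.1 degrees C higher from compound 1 to compound 3 (beyond the scatter) and a number 1.9 degrees C higher from compound 2 to compound 3 (beyond the scatter).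

Compound 4 `CC(C)(C)c1cc(NC(=O)Nc2ccc(Cl)cc2)n(-c2ccc(NC(=O)C3CC3)cc2)n1` differs from compound 3 in one place: (cyclopropylcarbonyl)amino in place of methylsulfonyl on an aromatic carbon. Among the compounds with values here, no measured step exchanges methylsulfonyl for an amide, so the measured steps bear on this change only in showing that the group at this place moves the shift by up to the size of a number 4.1 degrees C higher from compound 1 to compound 3 (beyond the scatter). A modest step down from the top value is therefore expected, namely a number 1.6 degrees C lower from compound 3 to compound 4 (beyond the scatter). Compound 4 is expected at 2.5 degrees C, with a range from 0 degrees C to 5 degrees C.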

Compound 4, shift of the target's melting temperature: 3.4 degrees C
Beside the measured number, compound 4's estimate is 0.90 degrees C below it, within the range that was stated.
By their numbers in this assay, from the lowest: compound 1; then compound 2; then compounds 4 and 3 (each within the scatter of the next).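

With a number 0.70 degrees C lower from compound 3 to compound 4 (within the scatter) this place on the aromatic ring takes (cyclopropylcarbonyl)amino as well as methylsulfonyl in this assay so a high shift is reached both with and without a hydrogen-bond donor in the group. The amide also stands clear of the two other groups, with a number 1.2 degrees C higher from compound 2 to compound 4 (beyond the scatter) and a number 3.4 degrees C higher from compound 1 to compound 4 (beyond the scatter) so the high shift is not tied to methylsulfonyl alone.

On these data alone, whether an amine, a carboxylic acid or a longer chain on the carbonyl would hold the shift at this place stays open. Nothing at hand explains the ranking of these groups.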